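The compounds below may be only part of what the source reports. "The series", "measured", "known", "first", "only" and "open" are said of these compounds alone.

Measured compounds:
- compound 1, `CCCCCCCCC(=O)N1c2ccccc2CCC1C(=O)Nc1ccccc1C(F)(F)F`: 8330 nM
- compound 2, `O=C(Nc1cc(C(F)(F)F)cc(C(F)(F)F)c1)C1CCc2ccccc2N1C(=O)c1ccc(Cl)cc1`: 2570 nM

In a functional assay on ACHN cells (Homo sapiens) for cytotoxicity, read by sulforhodamine B assay, with a stated time of 72 h (on this read-out higher numbers stand for weaker inhibition of growth and lower numbers for stronger inhibition of growth), compound 2 gives the lower of the two numbers shown, and compound 1, with a value of 8330 nM, stands clearly apart from it, beyond the usual scatter. Compound 2 is thus the stronger of the two on this read-out.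

Compound 3, `O=C(Nc1cc(C(F)(F)F)cc(C(F)(F)F)c1)C1CCc2ccccc2N1`, is the one still to be measured. It differs from compound 2 in a single place: hydrogen in place of (4-chlorophenyl)carbonyl on a nitrogen on an aromatic ring in a ring. The whole (4-chlorophenyl)carbonyl is removed and nothing but a hydrogen remains on that ring nitrogen.

Among the measured compounds shown here, no measured pair shows this change, so its effect is unknown here. The author expects that losing so large a group will weaken growth inhibition, with a step of a 3.9-fold higher number from compound 2 to compound 3 (0.59 log units; beyond the scatter) that reaches beyond the scatter. For compound 3 the estimated value in this assay is 10000 nM, within a range from 3000 nM to 40000 nM.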

Compound 3, concentration for 50% growth inhibition: 8190 nM
Beside the measured number, compound 3's estimate is 1.2-fold (0.09 log units) above it, within the range that was stated.
By their numbers in this assay, from the lowest: compound 2; then compounds 3 and 1 (each within the scatter of the next).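

Taking the (4-chlorophenyl)carbonyl off the ring nitrogen gives, in this assay, a 3.2-fold higher number from compound 2 to compound 3 (0.50 log units; beyond the scatter), the first reading of any change at this position. With the rest of compound 2 held constant, the group on this nitrogen therefore contributes to growth inhibition, but the effect is modest: with only hydrogen there, compound 3 still gives 8190 nM and growth inhibition is not lost. The data offer no measured explanation for this step.

On these data alone, what remains open is whether the gain needs the whole (4-chlorophenyl)carbonyl or whether a plain benzoyl group, an acetyl group or a benzyl group on that nitrogen would serve equally well. As far as these compounds go, it is also open whether the same change would give a step of similar size with a different amide partner, such as an unsubstituted anilide.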